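Para-substituent variation on the chalcone core: imidazolyl next

The compounds below may be only part of what the source reports. "The series", "measured", "known", "first", "only" and "open" are said of these compounds alone.

Notes on three measured analogues in a functional assay on K562 cells (Homo sapiens) for antiproliferative activity, read by MTT assay, with a stated time of 24 h; a higher number here means a weaker inhibitor, a lower number a stronger inhibitor. Compound 1 `COc1ccc(C(=O)/C=C/c2ccc(N(C)C)cc2)c2c1C=CC(C)(C)O2` gives 3500 nM. Compound 3 `COc1ccc(C(=O)/C=C/c2ccc(N3CCCC3)cc2)c2c1C=CC(C)(C)O2` gives 6180 nM; compound 1 and compound 3 lie within the scatter of each other, the step being a 1.8-fold higher number from compound 1 to compound 3 (0.25 log units; within the scatter). Compound 2 `COc1ccc(C(=O)/C=C/c2ccc(-c3ccccc3)cc2)c2c1C=CC(C)(C)O2` gives > 10000 nM, which is a limit of this assay (the limit of > 10000 nM in this assay, at which 1 of the 3 values shown sits). Compound 4 `COc1ccc(C(=O)/C=C/c2ccc(-n3ccnc3)cc2)c2c1C=CC(C)(C)O2` carries 1H-imidazol-1-yl in place of pyrrolidin-1-yl on an aromatic carbon. The bearing steps are an at least 2.8-fold higher number from compound 1 to compound 2 (0.45 log units; beyond the scatter) and an at least 1.6-fold lower number from compound 2 to compound 3 (0.20 log units; that floor lies within the scatter): an aromatic ring on that carbon gave a higher number than either amine, while the two amines are indistinguishable. Compound 4 is therefore expected to give a higher number, a step of a 1.5-fold higher number from compound 3 to compound 4 (0.16 log units; within the scatter). Compound 4 is estimated at 9000 nM, with a range from 3000 nM to 30000 nM.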

Compound 4, half-maximal inhibitory concentration: > 10000 nM
Compound 4 was reported as a limit; the forecaster's own chance of this, stated with the estimate: 45%; middle value at least 1.1-fold (0.04 log units) from the limit.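

Compound 2 and compound 4 now both stand at a limit, so a second aromatic type of ring on this carbon, phenyl or 1H-imidazol-1-yl, ends in the same place: the limit of > 10000 nM in this assay, at which 2 of the 4 values shown sit. In this assay, replacing dimethylamino with 1H-imidazol-1-yl gives an at least 2.8-fold higher number from compound 1 to compound 4 (0.45 log units; beyond the scatter), while the change from pyrrolidin-1-yl gives an at least 1.6-fold higher number from compound 3 to compound 4 (0.20 log units; that floor lies within the scatter). The added ring nitrogen of 1H-imidazol-1-yl thus does not restore the number of compound 1.

The step between compound 2 and compound 4 cannot be read, as both values are limits. Going by these compounds, whether morpholin-4-yl or a primary amine on this carbon would match compound 1 stays open.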